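Chloro and fluoro exchanged on the phenyl group: compound 4

The source may hold more compounds than are shown below. What is called first, only, known or untested is meant among the compounds shown, and "the series" means these compounds.

Compound 1 `O=C(Nc1ccc2[nH]c(=O)oc2c1)C(=O)N1CCN(c2ccccc2)CC1`, compound 2 `O=C(Nc1ccc2[nH]c(=O)oc2c1)C(=O)N1CCN(c2ccc(F)cc2)CC1` and compound 3 `O=C(Nc1ccc2[nH]c(=O)oc2c1)C(=O)N1CCN(c2ccc(F)c(Cl)c2)CC1` share one core. In an ADME assay on the whole organism (Rattus norvegicus, strain Sprague-Dawley) for pharmacokinetics, using cassette dosing, at a dose of 0.5 mg/kg by the intravenous route (a higher number here means faster removal of the compound, a lower number slower removal), compound 1 has no number: "not determined" (no result reported). Compound 2 gives 11.1 mL/min/kg. Compound 3 gives 18.3 mL/min/kg, within the scatter of compound 2, and compound 1 offers no further comparison.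

Compound 4 `O=C(Nc1ccc2[nH]c(=O)oc2c1)C(=O)N1CCN(c2ccc(Cl)c(F)c2)CC1` has the same atoms as compound 3, joined differently: 4-chloro-3-fluorophenyl in place of 3-chloro-4-fluorophenyl on an amine nitrogen in a ring. It carries 4-chloro-3-fluorophenyl in place of 3-chloro-4-fluorophenyl on an amine nitrogen in a ring.

Going by the values given here, only one measured step bears on this change: a 1.6-fold higher number from compound 2 to compound 3 (0.22 log units; within the scatter), with chloro in place of hydrogen on an aromatic carbon. Among the compounds with values here, no measured pair exchanges chloro and fluoro, so the evidence is indirect. As far as these compounds go, with that single step inside the scatter, no step beyond the scatter is expected in this assay, and the direction stays open. The expected step is a 1.1-fold lower number from compound 3 to compound 4 (0.03 log units; within the scatter).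

For compound 4 the estimated clearance is 17 mL/min/kg, with an expected range of 9 mL/min/kg to 32 mL/min/kg.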

Compound 4, clearance: 5.6 mL/min/kg
The estimate for compound 4 lay 3.0-fold (0.48 log units) above the measured number; the whole stated range lies above it.
By their numbers in this assay, from the lowest: compounds 4, 2 and 3 (each within the scatter of the next, the first and the last beyond it).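

Going by these compounds alone, exchanging the two halogens on the phenyl group, with the atoms unchanged, gives the first step beyond the scatter in this assay: a 3.3-fold lower number from compound 3 to compound 4 (0.51 log units; beyond the scatter). This shows that the number at this position depends on how chloro and fluoro are arranged, not only on their presence, although the step is modest. Measured against the 4-fluorophenyl group, neither arrangement moves beyond the scatter, with a 1.6-fold higher number from compound 2 to compound 3 (0.22 log units; within the scatter) and a 2.0-fold lower number from compound 2 to compound 4 (0.30 log units; within the scatter), so the separation is clear only between the two isomers, and no measurement shown here explains it.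

As far as these compounds go, whether this sensitivity to arrangement extends to a nitrile or a methoxy group on the phenyl group remains open. Also open, from the compounds shown here alone, is whether a dichlorophenyl or difluorophenyl group would follow the same pattern.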